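A second methyl on compound 3

This account rests on a few compounds, and the source may have more. Where it says the series, first, only, none or still open, it means among the compounds named here.

In a functional assay on cells (Tumor Cell line, Homo sapiens) for antiproliferative activity (a lower number here means a stronger inhibitor of growth, a higher number a weaker inhibitor of growth), compound 1 `Oc1cc(-c2ccc3ccccc3c2)nc2ncccc12` gives 8130 nM, compound 2 `Cc1ccnc2nc(-c3ccc4ccccc4c3)cc(O)c12` gives 1200 nM and compound 3 `Cc1ccc2c(O)cc(-c3ccc4ccccc4c3)nc2n1` gives 4570 nM. Compound 3 therefore lies within the scatter of compound 1 and clearly higher than compound 2, which has the lowest number. Compound 4 `Cc1cc(C)c2c(O)cc(-c3ccc4ccccc4c3)nc2n1` keeps the methyl of compound 3 and adds a methyl on the same carbon as in compound 2: methyl in place of hydrogen on an aromatic carbon. That change, made on compound 1, gave a 6.8-fold lower number from compound 1 to compound 2 (0.83 log units; beyond the scatter), whereas the methyl of compound 3 gave only a 1.8-fold lower number from compound 1 to compound 3 (0.25 log units; within the scatter). The first step is the closer precedent, so a drop of similar size is expected, although it rests on one pair. The expected step is a 5.7-fold lower number from compound 3 to compound 4 (0.76 log units; beyond the scatter). For compound 4 the estimated value is 800 nM, within a range of 250 nM to 2500 nM.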

Compound 4, concentration for 50% growth inhibition: 13500 nM
For compound 4 the middle estimate is 17-fold (1.23 log units) below the measured one; measured number above the stated range.
By their numbers in this assay, from the lowest: compound 2; then compounds 3, 1 and 4 (each within the scatter of the next, the first and the last beyond it).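

Placed opposite the ring nitrogen, the methyl gives a 3.0-fold higher number from compound 3 to compound 4 (0.47 log units; beyond the scatter), so its effect depends on the core that carries it: the same change on two cores in this assay, a 6.8-fold lower number (0.83 log units; beyond the scatter) from compound 1 to compound 2 and a 3.0-fold higher number (0.47 log units; beyond the scatter) from compound 3 to compound 4, 20-fold (1.30 log units) apart, beyond the scatter of two such steps.
The two methyl groups therefore do not simply add up, and the second route to compound 4 confirms this, with an 11-fold higher number from compound 2 to compound 4 (1.05 log units; beyond the scatter) on adding the other methyl: the same change on two cores in this assay, a 1.8-fold lower number (0.25 log units; within the scatter) from compound 1 to compound 3 and an 11-fold higher number (1.05 log units; beyond the scatter) from compound 2 to compound 4, 20-fold (1.30 log units) apart, beyond the scatter of two such steps.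

Why the two methyl groups fail to add up stays open. An amine or a longer chain at this place on compound 3 could tell whether the higher number follows any added group or the methyl alone.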